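Aryl swap on the pyridinone of compound 3

This account rests on a few compounds, and the source may have more. Where it says the series, first, only, none or still open, it means among the compounds named here.

The series shares a sulfonamide-bearing hydrazone arm; in a functional assay on HepG2 cells (Homo sapiens) for cytotoxicity, read by sulforhodamine B assay, with a stated time of 48 h (on this read-out lower numbers stand for stronger inhibition and higher numbers for weaker inhibition), compound 1 `C/C(=N\NC(=O)CC#N)c1ccc(NS(=O)(=O)c2ccc(Cl)cc2)cc1` gives 8000 nM and compound 2 `CCO/C=C(\C#N)C(=O)N/N=C(\C)c1ccc(NS(=O)(=O)c2ccc(Cl)cc2)cc1` gives 16800 nM. Compound 3 `CCOC(=O)c1c(-c2ccccc2OC)c(C#N)c(=O)n(/N=C(\C)c2ccc(NS(=O)(=O)c3ccc(Cl)cc3)cc2)c1N` carries this arm on a larger core and in this assay gives 11400 nM, which against compound 1 and compound 2 lies within the usual scatter on either side, so the three cannot be ranked. Among the compounds with values here, the only step available, a 2.1-fold higher number from compound 1 to compound 2 (0.32 log units; beyond the scatter), sits on the carbonyl side of the hydrazone and not on the aryl substituent of the core; it is modest and does not bear directly on the change now under consideration.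

Compound 4 `CCOC(=O)c1c(-c2cccc([N+](=O)[O-])c2)c(C#N)c(=O)n(/N=C(\C)c2ccc(NS(=O)(=O)c3ccc(Cl)cc3)cc2)c1N` differs from compound 3 by 3-nitrophenyl in place of 2-methoxyphenyl on an aromatic carbon. Within the data shown here, no measured pair in this set probes that position, so nothing indicates a shift beyond the scatter. The step of a 1.0-fold lower number from compound 3 to compound 4 (0.02 log units; within the scatter) is therefore expected to be small. For compound 4 in this assay the estimate is 11000 nM, with a range from 5000 nM to 25000 nM.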

Compound 4, half-maximal inhibitory concentration: 29700 nM
Estimate against measurement, compound 4: 2.7-fold (0.43 log units) below, and the stated range ends below it.
By their numbers in this assay, from the lowest: compounds 1, 3, 2 and 4 (each within the scatter of the next, the first and the last beyond it).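

In this assay the aryl position on the shared core, opposite the ring nitrogen, is not silent: 3-nitrophenyl in place of 2-methoxyphenyl gives a 2.6-fold higher number from compound 3 to compound 4 (0.42 log units; beyond the scatter). Within the data shown here, this is the first reading at this position, as the earlier step sat on the carbonyl side of the hydrazone, and here 2-methoxyphenyl gives the lower number, though the step remains modest. No measured finding on hand accounts for the shift.

This step changes both the substituent and its place on the phenyl ring, so the two effects cannot be separated from the compounds shown. Also open, on these data alone, is how this position responds to an unsubstituted phenyl, or to a phenyl bearing an amine or a carboxylic acid, and whether any such group would move the number lower than 2-methoxyphenyl does.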